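Swapping the Ring on the Urea Nitrogen in Rats

The source may report more compounds than this note shows. Statements on the series, on what has been measured and on what is new or still open speak of the compounds shown alone.

Compound 2 `COc1cc(C)nc(OC)c1NC(=O)N(Cc1ccc(Oc2ccc(F)cc2)cc1)C1CCCCCC1` gives 4.5 mg/kg in a functional assay on the whole organism with Rattus norvegicus as the target (on this read-out lower numbers stand for an effect already at smaller amounts and higher numbers for an effect only at larger amounts of compound), the highest of the two numbers measured. Compound 1 `CSc1nc(C)nc(SC)c1NC(=O)N(Cc1ccc(Oc2ccc(F)cc2)cc1)C1CCCCCC1` gives 0.45 mg/kg in this assay. Among the measured compounds shown here, the only measured step is a 10-fold higher number from compound 1 to compound 2 (1.00 log units; beyond the scatter). Compound 3 `Cc1cc(S(C)(=O)=O)c(NC(=O)N(Cc2ccc(Oc3ccc(F)cc3)cc2)C2CCCCCC2)c(Cl)n1` differs from compound 2 by a group of 12 heavy atoms (7 carbon, 1 nitrogen, 2 oxygen, 1 sulfur, 1 chlorine; one six-membered aromatic ring with 1 hetero atom) in place of a group of 11 heavy atoms (8 carbon, 1 nitrogen, 2 oxygen; one six-membered aromatic ring with 1 hetero atom), on an amide-type nitrogen. For the measured compounds named here, no measured step covers this exact exchange; the one known step, which also replaced the whole ring on the amide-type nitrogen, was modest in size. A step of similar or smaller size is therefore expected, leaning toward a lower number. Compound 3 is estimated at 2 mg/kg, between 0.5 mg/kg and 8 mg/kg, an expected step of a 2.3-fold lower number from compound 2 to compound 3 (0.35 log units; beyond the scatter).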

Compound 3, dose for half-maximal effect: > 1 mg/kg
Compound 3 gave a limit, no number (the forecaster's own chance of this, stated with the estimate: 10%); the middle value does not contradict the limit.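

In this assay compound 3 gives > 1 mg/kg, which is a limit of the assay and not a number. Even so, it can be compared with the best result here: the change shows an at least 2.2-fold higher number from compound 1 to compound 3 (0.34 log units; beyond the scatter), so a second replacement ring on the amide-type nitrogen, this one holding sulfur and chlorine, also fails to match the ring of compound 1. The step from compound 2 to compound 3 cannot be read.

Which of these two rings needs the smaller dose therefore stays open. So does the effect of an amine or a carboxylic acid on the ring at this position.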